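A Change at the Ring Nitrogen of Compound 3

A few compounds are considered here, and "the series" means these few. Any claim that something is new, unique, unknown or untested is made for them only; others in the source may bear on it.

Of the compounds shown here, three built on one shared core have been tested in a functional assay on the whole organism (strain Kunming) for inhibition, with Mus musculus as the target, with a stated time of 1 h, at a dose of 40 mg/kg by the oral route; a lower number here means less inhibition, a higher number more inhibition at the dose given (going by the name of the read-out). Compound 1 `Cc1ccc(N2CCN(c3ccc(C(=O)/C=C/c4ccccc4)cc3)CC2)c(C)c1` gives 15%. Compound 2 `COc1ccc(/C=C/C(=O)c2ccc(N3CCN(c4ccc(C)cc4C)CC3)cc2)cc1OC` gives 48.5%. Compound 3 `Cc1ccc(N2CCN(c3ccc(C(=O)/C=C/c4ccc(Cl)cc4)cc3)CC2)c(C)c1` gives 25.7%. Among these three numbers compound 3 stands second highest: a number 10.7 percentage points higher from compound 1 to compound 3 (beyond the scatter), while a number 22.8 percentage points lower from compound 2 to compound 3 (beyond the scatter). The remaining step, a number 33.5 percentage points higher from compound 1 to compound 2 (beyond the scatter), alters the same end of the molecule, the phenyl on a double-bonded chain carbon.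

Compound 4 `COc1ccc(N2CCN(c3ccc(C(=O)/C=C/c4ccc(Cl)cc4)cc3)CC2)cc1` differs from compound 3 at a different place: 4-methoxyphenyl in place of 2,4-dimethylphenyl on an amine nitrogen in a ring. None of the three measured steps touches this part of the molecule; each of them changes only the group on the double-bonded chain carbon, which in compound 3 and compound 4 is the same 4-chlorophenyl. The three steps already in hand therefore give no guide to the size or direction of this change. The change is expected to amount to a number 0.3 percentage points higher from compound 3 to compound 4 (within the scatter), a step within the scatter, with a wide range set to allow for movement either way. On that basis compound 4 is expected to give 26%, with a likely range from 10% to 45%.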

Compound 4, a percentage reported as inhibition, in the whole organism at one dose (the size of the read-out at that dose, not a potency): 55.1%
Estimate against measurement, compound 4: 29.1 percentage points below; measured number outside the range, above it.
By their numbers in this assay, from the lowest: compound 1; then compound 3; then compounds 2 and 4 (each within the scatter of the next).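

In this assay, the group on the amine nitrogen in the ring proves to matter: with the 4-chlorophenyl at the other end held fixed, 4-methoxyphenyl in place of 2,4-dimethylphenyl gives a number 29.4 percentage points higher from compound 3 to compound 4 (beyond the scatter). For the compounds shown here, all the earlier steps changed only the group on the double-bonded chain carbon, so this is the first sign that the opposite end of the molecule can also shift the inhibition seen at this dose, even though the leaving and entering groups have the same heavy-atom count and each holds one six-membered aromatic ring of carbon only. The entering group does carry one hydrogen-bond acceptor where the leaving group has none, but no measurement available here explains the rise.

This single step removes both methyl groups and adds the methoxy at once, so the compounds shown cannot say which part of the swap matters; an unsubstituted phenyl or a 4-methylphenyl on the same nitrogen would help separate the two. Also open, as far as these compounds go, is whether 4-methoxyphenyl on this nitrogen would give a similar step with phenyl or 3,4-dimethoxyphenyl at the other end of the molecule.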